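The source may hold more compounds than are shown below. What is called first, only, known or untested is meant among the compounds shown, and "the series" means these compounds.

Measured in a functional assay on Bel-7402 cells (Homo sapiens) for antiproliferative activity, read by MTT assay, with a stated time of 72 h; on this read-out lower numbers stand for stronger inhibition and higher numbers for weaker inhibition:
- compound 1 `C=C1C(=O)O[C@H]2[C@H]1CC/C(COC(=O)CCC(=O)NCCCCCCNC(=O)Cn1cc(F)c(=O)[nH]c1=O)=C\CC[C@@]1(C)O[C@@H]21`: > 20000 nM
- compound 2 `C=C1C(=O)O[C@H]2[C@H]1CC/C(COC(=O)Cn1cc(F)c(=O)n(Cc3ccccc3)c1=O)=C\CC[C@@]1(C)O[C@@H]21`: 3980 nM
- compound 3 `C=C1C(=O)O[C@H]2[C@H]1CC/C(Cn1cc(Cn3cc(F)c(=O)n(Cc4ccccc4)c3=O)nn1)=C\CC[C@@]1(C)O[C@@H]21`: 9160 nM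

Compound 1 gives > 20000 nM, which is a limit of this assay and not a number.

Within the data shown here, only two numbers are therefore available. Compound 2, at 3980 nM, holds the lower of them. The other belongs to compound 3, at 9160 nM, and the gap between the two lies beyond the usual scatter.

The next compound to be read is compound 4 `C=C1C(=O)O[C@H]2[C@H]1CC/C(COC(=O)Cn1cc(F)c(=O)n(Cc3ccc(C(F)(F)F)cc3)c1=O)=C\CC[C@@]1(C)O[C@@H]21`. It differs from compound 2 by trifluoromethyl in place of hydrogen on an aromatic carbon, para to a large group, so that benzyl becomes 4-(trifluoromethyl)benzyl.

Among the measured compounds shown here, no measured pair tests a change on this benzyl ring, so the expectation rests on compound 2 at 3980 nM as the only close reference. No step beyond the scatter is expected, with a slight lean toward a lower number. The estimated step is a 1.3-fold lower number from compound 2 to compound 4 (0.12 log units; within the scatter).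

For compound 4 the expected value is 3000 nM, with an estimated range of 1200 nM to 8000 nM.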

Compound 4, half-maximal inhibitory concentration: 2250 nM
For compound 4 the middle estimate is 1.3-fold (0.12 log units) above the measured one; the measured number falls inside the stated range.
By their numbers in this assay, from the lowest: compounds 4 and 2 (each within the scatter of the next); then compound 3. At a limit, above all of these: compound 1.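

Notes on the benzyl ring: this is the first pair in the series that tests a change on that ring, at the aromatic carbon para to a large group. In this assay, trifluoromethyl in place of hydrogen gives a 1.8-fold lower number from compound 2 to compound 4 (0.25 log units; within the scatter), so compound 2 and compound 4 cannot be told apart on this read-out, and this position carries trifluoromethyl with neither a gain nor a loss beyond the scatter. None of the information on hand bears on why the step has this size, and a single pair gives no trend for the ring.

Going by these compounds, the reading rests on one substituent at one position, so it remains open whether an amine, a carboxylic acid, a methoxy group or a longer alkyl chain at the same carbon would give a step beyond the scatter. Among these compounds, it is also open whether 4-(trifluoromethyl)benzyl in place of benzyl on compound 3 would give a step of similar size, since the only evidence for this change comes from the ester-linked compounds.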